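A few compounds are considered here, and "the series" means these few. Any claim that something is new, unique, unknown or untested is made for them only; others in the source may bear on it.

Three compounds share one core and differ only in the group on a saturated chain carbon bound to an aromatic nitrogen. Compound 1 `O=C(NN[C@@H]1O[C@H](CO)[C@@H](O)[C@H](O)[C@H]1O)c1cc(-c2ccc(Cl)cc2)nn1Cc1ccc(Cl)nc1` carries 6-chloropyridin-3-yl there and in a functional assay on A549 cells (Homo sapiens) for inhibition, read by sulforhodamine B assay, with a stated time of 48 h (a higher number here means a weaker inhibitor, a lower number a stronger inhibitor), compound 1 gives 35000 nM. Compound 2 `CC(C)(C)c1ccc(Cn2nc(-c3ccc(Cl)cc3)cc2C(=O)NN[C@@H]2O[C@H](CO)[C@@H](O)[C@H](O)[C@H]2O)cc1` carries 4-(tert-butyl)phenyl, and in this assay compound 2 gives 26600 nM. Compound 3 `O=C(NN[C@@H]1O[C@H](CO)[C@@H](O)[C@H](O)[C@H]1O)c1cc(-c2ccc(Cl)cc2)nn1Cc1ccccc1` carries phenyl, and in this assay compound 3 gives 31800 nM. Compound 2 stands among three numbers that lie within the scatter of one another: a 1.3-fold lower number from compound 1 to compound 2 (0.12 log units; within the scatter), a 1.1-fold lower number from compound 1 to compound 3 (0.04 log units; within the scatter) and a 1.2-fold higher number from compound 2 to compound 3 (0.08 log units; within the scatter).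

Compound 4 `CC(C)(C)c1ccc(Cn2nc(-c3ccccc3)cc2C(=O)NN[C@@H]2O[C@H](CO)[C@@H](O)[C@H](O)[C@H]2O)cc1` differs from compound 2 by hydrogen in place of chloro on an aromatic carbon. Going by the values given here, none of the measured steps touches the 4-chlorophenyl; all three concern the group on the saturated chain carbon bound to the aromatic nitrogen, and all three stayed within the scatter. Among the compounds with values here, no measured step therefore bears directly on this change, and in this assay no step beyond the scatter is expected in either direction. Compound 4 is expected to give 28000 nM, within a range from 12000 nM to 65000 nM, which means an expected step of a 1.1-fold higher number from compound 2 to compound 4 (0.02 log units; within the scatter).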

Compound 4, half-maximal inhibitory concentration: 21600 nM
Estimate against measurement, compound 4: 1.3-fold (0.11 log units) above; low and high end bracket the measured number.
By their numbers in this assay, from the lowest: compounds 4, 2, 3 and 1 (each within the scatter of the next).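

Going by these compounds alone, this change reaches a part of the molecule that the earlier steps left untouched: in this assay, hydrogen in place of chloro on the aromatic carbon para to a large group gives a 1.2-fold lower number from compound 2 to compound 4 (0.09 log units; within the scatter). With the 4-(tert-butyl)phenyl group held constant, the change from 4-chlorophenyl to phenyl therefore stays within the scatter, as did all three steps at the saturated chain carbon. None of the data shown accounts for this result.

From the compounds shown here alone, the change is seen here only with 4-(tert-butyl)phenyl on the chain carbon, so its outcome alongside phenyl or 6-chloropyridin-3-yl remains open. Also open, going by these compounds, is what an amine, a carboxylic acid or a methoxy group on that aromatic carbon would give in this assay, and whether any group there would produce a step beyond the scatter.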